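The source may hold more compounds than are shown below. What is called first, only, known or untested is meant among the compounds shown, and "the series" means these compounds.

In an ADME assay on MRC5 cells (Homo sapiens), read by MTT assay, with a stated time of 72 h (a higher number here means a weaker inhibitor, a lower number a stronger inhibitor), compound 1 `CSc1ncnc2c1c(-c1ccsc1)cn2[C@@H]1O[C@H](CO)[C@@H](O)[C@H]1O` gives only a limit, > 100000 nM. Compound 2 `Cc1ncnc2c1c(-c1ccoc1)cn2[C@@H]1O[C@H](CO)[C@@H](O)[C@H]1O` gives a measured number, 98300 nM. Compound 3 `Cc1ncnc2c1c(-c1cccs1)cn2[C@@H]1O[C@H](CO)[C@@H](O)[C@H]1O` also gives only a limit, > 100000 nM. Compound 3 thus shares (the limit of > 100000 nM in this assay, at which 2 of the 3 values shown sit), so its true value is not known.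

Compound 4 `Cc1ncnc2c1c(-c1ccsc1)cn2[C@@H]1O[C@H](CO)[C@@H](O)[C@H]1O` has the same atoms as compound 3, joined differently: thiophen-3-yl in place of thiophen-2-yl on an aromatic carbon. In words, thiophen-3-yl stands in place of thiophen-2-yl on an aromatic carbon of the shared core.

Within the data shown here, the one measured step that bears on this is a similar swap of one aromatic group for another at the same place, thiophen-2-yl in place of furan-3-yl. That step is an at least 1.0-fold higher number from compound 2 to compound 3 (0.00 log units; that floor lies within the scatter). It gives no sign of a large effect from this group, although the limit on compound 3 hides how large the step really is. No change beyond the scatter is therefore expected in this assay, in either direction.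

The expected step is a number no higher from compound 3 to compound 4 (the limit leaves the size open). Compound 4 is estimated at 100000 nM, with an expected range from 45000 nM to 200000 nM.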

Compound 4, half-maximal inhibitory concentration: > 100000 nM
Compound 4 gave a limit, no number (the forecaster's own chance of this, stated with the estimate: 65%); the middle value lies on the limit itself.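

With thiophen-3-yl in place of furan-3-yl, the result is an at least 1.0-fold higher number from compound 2 to compound 4 (0.00 log units; that floor lies within the scatter), so this swap, like the one to thiophen-2-yl, shows no change beyond the scatter at this position. The steps from compound 3 and from compound 1 to compound 4 cannot be read, as both ends of each are limits. The effect of how the thiophene ring is joined therefore cannot be sized, nor can that of methyl in place of methylsulfanyl, and the limit now covers most of this small set: the limit of > 100000 nM in this assay, at which 3 of the 4 values shown sit.

Going by these compounds, whether a phenyl ring or an amine on this aromatic carbon would bring the number clearly down in this assay remains open. Also open, on these data alone, is how far the true values of compound 1, compound 3 and compound 4 lie past the limit.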